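The source may report more compounds than this note shows. Statements on the series, on what has been measured and on what is new or still open speak of the compounds shown alone.

Among the measured compounds shown here, compound 2 `O=c1c2ccccc2sn1NCc1ccccc1` gives the lowest of the two numbers known so far: in an assay on HeLa cells for inhibition of Monoglyceride lipase (Rattus norvegicus), read by LC-MS, with a stated time of 10 min (a lower number here means a stronger inhibitor, a higher number a weaker inhibitor), compound 2 gives 19.5 nM, whereas compound 1 `Cn1sc2ccccc2c1=O` gives 59.5 nM, a gap beyond the scatter. Compound 3 `COC(=O)c1ccc(CNn2sc3ccccc3c2=O)cc1` differs from compound 2 by methoxycarbonyl in place of hydrogen on an aromatic carbon, on an aromatic carbon of a six-membered aromatic ring of carbon only, para to a large group. For the measured compounds named here, no measured pair shows this change, so its effect in this assay is unknown; a modest step in either direction, or none beyond the scatter, is expected. Compound 3 is estimated at 15 nM, between 5 nM and 50 nM, an expected step of a 1.3-fold lower number from compound 2 to compound 3 (0.11 log units; within the scatter).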

Compound 3, half-maximal inhibitory concentration: 93.9 nM
For compound 3 the middle estimate is 6.3-fold (0.80 log units) below the measured one; measured number outside the range, above it.
By their numbers in this assay, from the lowest: compound 2; then compounds 1 and 3 (each within the scatter of the next).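

In this assay, among the compounds shown here, methoxycarbonyl in place of hydrogen on an aromatic carbon, para to a large group, gives a 4.8-fold higher number from compound 2 to compound 3 (0.68 log units; beyond the scatter) and so provides the first reading at this position: it is not indifferent to what it carries, and this group costs potency there. No measurement at hand accounts for the loss. The compounds shown leave open whether a small atom such as fluorine, a methyl group or a carboxylic acid at the same place would cost as much. They also leave open whether methoxycarbonyl would give a similar loss elsewhere on that ring.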